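This account rests on a few compounds, and the source may have more. Where it says the series, first, only, none or still open, it means among the compounds named here.

Working notes on the series. In a functional assay on U-87MG ATCC cells for antiproliferative activity against U-87 MG (Homo sapiens), read by MTT assay, with a stated time of 48 h, tested at 5 uM (on this read-out lower numbers stand for a stronger effect and higher numbers for a weaker effect at the one concentration tested), compound 1 `COc1ccc(-c2nc(C)c(C(=O)CSc3nc(N)c(C#N)c(-c4ccc(Cl)cc4)n3)s2)cc1` gives 51.4%, the lowest of the three numbers on hand. Compound 2 `Cc1nc(-c2ccc(Cl)cc2)sc1C(=O)CSc1nc(-c2ccccc2)c(C#N)c(=O)[nH]1` gives 88.9% in this assay, and compound 3 `COc1ccc(-c2nc(SCC(=O)c3sc(-c4ccccc4)nc3C)[nH]c(=O)c2C#N)cc1` gives 97.3%; both lie beyond the scatter above compound 1, so compound 1 shows the strongest effect of the measured set.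

Compound 4 `COc1ccc(-c2nc(C)c(C(=O)CSc3nc(N)c(C#N)c(-c4ccccc4)n3)s2)cc1` differs from compound 1 in a single place: hydrogen in place of chloro on an aromatic carbon. Within the data shown here, no measured pair shows this same change, so its size cannot be read from the data; the expectation is a small weakening of the effect, possibly within the scatter. Compound 4 is estimated at 60%, with a range from 42% to 82%, meaning an expected step of a number 8.6 percentage points higher from compound 1 to compound 4 (within the scatter).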

Compound 4, a percentage reported as activity, at one concentration (the size of the read-out at that concentration, not a potency): 61.8%
Beside the measured number, compound 4's estimate is 1.8 percentage points below it; measured number inside the range.
By their numbers in this assay, from the lowest: compound 1; then compound 4; then compounds 2 and 3 (each within the scatter of the next).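

In this assay the change from 4-chlorophenyl to phenyl gives a number 10.4 percentage points higher from compound 1 to compound 4 (beyond the scatter) and so puts a first, modest size on what the chloro contributes at this aromatic carbon. Among these compounds, this is the only single-place step so far, and it shows that this position affects the read-out. No measurement on hand accounts for the step.

Going by these compounds, whether a fluoro, methyl or methoxy group here would match the chloro remains open. So does whether the same change would give a similar step on other cores.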